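Tetrazole in place of carboxylic acid on the saturated chain

This account rests on a few compounds, and the source may have more. Where it says the series, first, only, none or still open, it means among the compounds named here.

Compound 1 `c1cc(OCCCc2nnn[nH]2)cc(OCc2ccc3ccccc3n2)c1` and compound 2 `CC(CCCc1cccc(OCc2ccc3ccccc3n2)c1)C(=O)O` share a core and differ in the chain. In an assay on membranes from lung (Cavia porcellus) for binding affinity to cysteinyl leukotriene receptor (Homo sapiens) (on this read-out lower numbers stand for stronger inhibition and higher numbers for weaker inhibition), compound 1 gives 42 nM; compound 2 gives 85 nM, the highest of the two numbers, with a 2.0-fold higher number from compound 1 to compound 2 (0.31 log units; beyond the scatter). Compound 3 `c1cc(CCCCc2nnn[nH]2)cc(OCc2ccc3ccccc3n2)c1` carries (1H-tetrazol-5-yl)methyl in place of 1-carboxyethyl on a saturated chain carbon, three bonds along the chain from an aromatic carbon. The step from compound 1 to compound 2 is the one that bears on this change, as it runs the other way; a modest drop in this assay is therefore expected for compound 3, about a 2.1-fold lower number from compound 2 to compound 3 (0.33 log units; beyond the scatter). Compound 3 is estimated at 40 nM, expected between 15 nM and 110 nM.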

Compound 3, inhibition constant: 20 nM
The estimate for compound 3 lay 2.0-fold (0.30 log units) above the measured number, and the stated range covers the measured number.
By their numbers in this assay, from the lowest: compound 3; then compound 1; then compound 2.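

In this assay, among the compounds shown here, (1H-tetrazol-5-yl)methyl in place of 1-carboxyethyl gives a 4.3-fold lower number from compound 2 to compound 3 (0.63 log units; beyond the scatter), which sets the two end groups against each other on a saturated chain for the first time. With the tetrazole kept, 4-(1H-tetrazol-5-yl)butyl in place of 3-(1H-tetrazol-5-yl)propoxy gives a 2.1-fold lower number from compound 1 to compound 3 (0.32 log units; beyond the scatter), so the attachment of the chain to the aromatic carbon also counts, and compound 3 has the lowest number of the series. No measurement here explains either step.

The step from compound 2 also removes the methyl branch, so a straight chain ending in a carboxylic acid would be needed to separate the two parts of the change. From the compounds shown here alone, how a shorter or longer chain carrying the tetrazole would read remains open.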